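The source may hold more compounds than are shown below. What is called first, only, known or untested is meant among the compounds shown, and "the series" means these compounds.

Measured in a functional assay on HCT-116 cells (Homo sapiens) for cytotoxicity, read by MTT assay, with a stated time of 72 h; a lower number here means a stronger inhibitor, a higher number a weaker inhibitor:
- compound 1 `CC(C)NC(=S)N/N=C1\CC(c2ccc(O)cc2)Oc2cc(O)ccc21`: 38200 nM
- compound 2 `Oc1ccc(C2C/C(=N\NC(=S)N3CCCCC3)c3ccc(O)cc3O2)cc1`: 50900 nM

Compound 2, at 50900 nM, stands level with compound 1 within the scatter. Compound 3 `CCCNC(=S)N/N=C1\CC(c2ccc(O)cc2)Oc2cc(O)ccc21` follows from compound 2 by propylamino in place of piperidin-1-yl on a thiocarbonyl carbon, with propylamino in place of piperidin-1-yl on a thiocarbonyl carbon. Among the compounds with values here, one measured step bears on this change: a 1.3-fold higher number from compound 1 to compound 2 (0.12 log units; within the scatter), with piperidin-1-yl in place of isopropylamino at the same place. That step gives no reason to expect a shift beyond the scatter in this assay. The expected step is a 1.2-fold lower number from compound 2 to compound 3 (0.08 log units; within the scatter), so no real change is expected. For compound 3 the estimated value is 42000 nM, with an expected range of 22000 nM to 80000 nM.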

Compound 3, half-maximal inhibitory concentration: 54000 nM
For compound 3 the middle estimate is 1.3-fold (0.11 log units) below the measured one; low and high end bracket the measured number.
By their numbers in this assay, from the lowest: compounds 1, 2 and 3 (each within the scatter of the next).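

In this assay, propylamino, which has no ring and carries a hydrogen-bond donor, gives no real shift from piperidin-1-yl on the thiocarbonyl carbon (a 1.1-fold higher number from compound 2 to compound 3 (0.03 log units; within the scatter)). Propyl in place of isopropyl on the amide-type nitrogen also stays within the scatter (a 1.4-fold higher number from compound 1 to compound 3 (0.15 log units; within the scatter)), so isopropylamino, piperidin-1-yl and propylamino all stand level at this place. No supporting data offer an account of this flat response.

Going by these compounds, whether a longer chain, a phenyl ring or a carboxylic acid at this place would move the number beyond the scatter remains open. So does the effect of any change on the shared core.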